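The source may hold more compounds than are shown below. What is called first, only, known or untested is meant among the compounds shown, and "the series" means these compounds.

Compound 1 `CN1C/C(=C\c2ccc(C#N)cc2)C(=O)/C(=C/c2cccnc2)C1` in a functional assay on QGY-7703 cells (Homo sapiens) for cytotoxicity, read by MTT assay, with a stated time of 24 h (a higher number here means a weaker inhibitor, a lower number a stronger inhibitor), gives > 20000 nM, which is a limit of the assay rather than a number, (the limit of > 20000 nM in this assay, at which 1 of the 3 values shown sits). Compound 2 `CN1C/C(=C\c2ccncc2)C(=O)/C(=C/c2ccc(C#N)cc2)C1` gives 7400 nM. Compound 3 `O=C1/C(=C/c2cccnc2)CNC/C1=C\c1ccccc1C(F)(F)F` gives 3800 nM.

Compound 2 differs from compound 1 by pyridin-4-yl in place of pyridin-3-yl on a double-bonded chain carbon bound to a double-bonded ring carbon, and this change brought an at least 2.7-fold lower number from compound 1 to compound 2 (0.43 log units; beyond the scatter). The values of compound 3 and compound 2 lie within the usual scatter of each other. How the core of compound 3 differs from that of compound 1 is not broken down here.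

Compound 4 `O=C1/C(=C/c2ccncc2)CNC/C1=C\c1ccccc1C(F)(F)F` has not yet been measured in this assay. It differs from compound 3 by pyridin-4-yl in place of pyridin-3-yl on a double-bonded chain carbon bound to a double-bonded ring carbon, the same change as that from compound 1 to compound 2. Resting on the step that this change made from compound 1 to compound 2, a modest lowering of the number is expected, giving a 2.5-fold lower number from compound 3 to compound 4 (0.40 log units; beyond the scatter). Compound 4 is accordingly estimated at 1500 nM, with a plausible range from 500 nM to 5000 nM.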

Compound 4, half-maximal inhibitory concentration: 4900 nM
For compound 4 the middle estimate is 3.3-fold (0.51 log units) below the measured one, and the stated range covers the measured number.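

In this assay, pyridin-4-yl in place of pyridin-3-yl gave a 1.3-fold higher number from compound 3 to compound 4 (0.11 log units; within the scatter), so the lowering seen on the core of compound 1 did not carry over to the core of compound 3. The same change therefore gave different results on the two cores: the same change on two cores in this assay, an at least 2.7-fold lower number (0.43 log units; beyond the scatter) from compound 1 to compound 2 and a 1.3-fold higher number (0.11 log units; within the scatter) from compound 3 to compound 4, at least 3.4-fold (0.54 log units) apart, beyond the scatter of two such steps

Compound 1 gives > 20000 nM, which is a limit of the assay and not a number, and these two cores alone do not show which of their differences decides the outcome of the change.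

The compounds shown leave open how pyridin-2-yl or a carboxylic acid would fare on a double-bonded chain carbon bound to a double-bonded ring carbon. They also leave open how the change would behave on further cores.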